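A few compounds are considered here, and "the series" means these few. Any claim that something is new, unique, unknown or untested is made for them only; others in the source may bear on it.

In a functional assay, read by spectrophotometry, tested at 100 uM (a higher number here means a weaker inhibitor, a lower number a stronger inhibitor), compound 1 (`Cc1ccc(/C=C/C(=O)c2cccc(NC(=O)c3cc(-c4ccncc4)n[nH]3)c2)cc1`) gives 64600 nM as its half-maximal inhibitory concentration, while compound 2 (`O=C(/C=C/c1ccc(F)cc1)c1cccc(NC(=O)c2cc(-c3ccncc3)n[nH]2)c1`) gives 58700 nM and compound 3 (`O=C(/C=C/c1cccs1)c1cccc(NC(=O)c2cc(-c3ccncc3)n[nH]2)c1`) gives 70000 nM in the same measurement. These three numbers lie within the scatter of one another, so compound 1 holds no distinct rank among them. Compound 4 (`CN(C)c1ccc(/C=C/C(=O)c2cccc(NC(=O)c3cc(-c4ccncc4)n[nH]3)c2)cc1`) has yet to be measured. It carries dimethylamino in place of methyl on an aromatic carbon, para to a large group, and is otherwise the same as compound 1 (dimethylamino in place of methyl on an aromatic carbon). The closest measured step lies at that same carbon, where fluoro in place of methyl gave a 1.1-fold lower number from compound 1 to compound 2 (0.04 log units; within the scatter). Thiophen-2-yl in place of 4-methylphenyl gave a 1.1-fold higher number from compound 1 to compound 3 (0.03 log units; within the scatter), and thiophen-2-yl in place of 4-fluorophenyl gave a 1.2-fold higher number from compound 2 to compound 3 (0.08 log units; within the scatter). Among the compounds with values here, all three steps stayed within the scatter, but none of the measured compounds carries dimethylamino, so this evidence is indirect. No step beyond the scatter is therefore expected in this assay, in either direction. The expected step is a 1.1-fold lower number from compound 1 to compound 4 (0.03 log units; within the scatter), with a wide margin kept around it. Compound 4 is estimated at 60000 nM, with an expected range from 30000 nM to 100000 nM.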

Compound 4, half-maximal inhibitory concentration: 60900 nM
Compound 4: the middle estimate sits 1.0-fold (0.01 log units) below what was measured, within the range that was stated.
By their numbers in this assay, from the lowest: compounds 2, 4, 1 and 3 (each within the scatter of the next).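

In this assay, within the data shown here, dimethylamino in place of methyl on an aromatic carbon, para to a large group, gave a 1.1-fold lower number from compound 1 to compound 4 (0.03 log units; within the scatter), which shows that a group of 3 heavy atoms, including a nitrogen and a hydrogen-bond acceptor, leaves the number within the scatter where the earlier compounds had tested only methyl and fluoro at this carbon. Dimethylamino in place of fluoro gave a 1.0-fold higher number from compound 2 to compound 4 (0.02 log units; within the scatter), and 4-(dimethylamino)phenyl in place of thiophen-2-yl gave a 1.1-fold lower number from compound 3 to compound 4 (0.06 log units; within the scatter), so all four compounds now stand within the scatter of one another, and no substituent shown at this position separates from the rest. Nothing measured here bears on why the number holds so steady across these changes.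

As far as these compounds go, it remains open whether a carboxylic acid, a primary amine or a longer chain on this same aromatic carbon would produce a step beyond the scatter. The compounds shown also leave open what a saturated chain in place of the double-bonded chain carbons would do, since every change so far lies at the far aromatic end of the shared core.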